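A few compounds are considered here, and "the series" means these few. Any claim that something is new, unique, unknown or untested is made for them only; others in the source may bear on it.

Measured so far in an ADME assay on HepG2 2.2.15 cells (Homo sapiens) for cytotoxicity; a higher number here means that more compound is tolerated, a lower number that less compound is tolerated:
compound 1, `O=C(CCCCC(=O)Nc1ncc(Cc2ccc(F)cc2)s1)Nc1ncc(Cc2ccc(F)cc2)s1`, > 50000 nM;
compound 2, `O=C(Nc1ncc(C(OCc2ccc(Cl)cc2)c2ccccc2)s1)c1cccs1`, "not toxic" (no number reported);
compound 3, `COCCCNc1ncc(C(Oc2ccc3cc(Br)ccc3c2)c2ccc(Cl)cc2)s1`, "not toxic" (no number reported).

The value of compound 1 is a limit of the assay, not a number. Compound 3 gives no single number in this assay; it stands beside one limit and one further entry without a number, so no value shown reports harm to the cells, and one of the three sits at the limit of > 50000 nM in this assay, at which 1 of the 3 values shown sits. Compound 4, `O=C(Nc1ncc(C(Oc2ccc3cc(Br)ccc3c2)c2ccc(Cl)cc2)s1)C1CC1`, differs from compound 3 by cyclopropylcarbonyl in place of 3-methoxypropyl on a nitrogen on an aromatic ring. For the measured compounds named here, no measured pair shows such a change, and no value shown points to harm to the cells; the expectation is therefore a step of no size beyond the scatter. In this assay compound 4 is expected to give 60000 nM, between 20000 nM and 200000 nM.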

Compound 4, half-maximal cytotoxic concentration: "not toxic" (no number reported)
For compound 4 the study gives words and no number; no gap can be computed for the estimate.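

For the compounds shown here, compound 3 and compound 4 are both reported only in the words "not toxic", so no step between them can be read. The compounds shown leave open at what concentration, if any, these structures harm the cells, and the only entry with a figure is a limit: the limit of > 50000 nM in this assay, at which 1 of the 4 values shown sits.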